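A Limit-Bound Series and One Swapped Aryl Group

The compounds below may be only part of what the source reports. "The series", "measured", "known", "first", "only" and "open" are said of these compounds alone.

In an ADME assay on BJ cells (Homo sapiens) for cytotoxicity, with a stated time of 72 h (on this read-out higher numbers stand for an effect only at larger amounts of compound and lower numbers for an effect already at smaller amounts), compound 1 (`COc1ccc(-c2nc3c(c(C)nn3-c3ccccc3)c(-c3ccccc3O)c2C#N)cc1`) stands at > 23000 nM which is a limit and not a number. Compound 2 (`CCc1ccc(-c2nc3c(c(C)nn3-c3ccccc3)c(-c3ccccc3C#N)c2C#N)cc1`) gives > 20000 nM and this too is a limit. Compound 3 (`CCc1ccc(-c2nc3c(c(C)nn3-c3ccccc3)c(-c3ccccc3)c2C#N)cc1`) gives > 20000 nM and this is again a limit. Among the measured compounds shown here, the only measured step (a step that the two limits leave unreadable from compound 2 to compound 3) has no readable size and concerns a different group. Compound 4 (`Cc1ccccc1-c1nc2c(c(C)nn2-c2ccccc2)c(-c2ccccc2O)c1C#N`) carries 2-methylphenyl in place of 4-methoxyphenyl on an aromatic carbon of the shared core. No measured step sizes this change, so in this assay no shift beyond the scatter is expected in either direction. The estimated step (a number no higher from compound 1 to compound 4 (the limit leaves the size open)) is expected to have no clear direction. Compound 4 is estimated at 23000 nM within an expected range of 10000 nM to 40000 nM and will probably be reported only as a limit.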

Compound 4, half-maximal effective concentration: 21000 nM
Compound 4: middle estimate off by 1.1-fold (0.04 log units), on the high side; the measured number falls inside the stated range.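

In this assay, among the compounds shown here, compound 4 gives 21000 nM, the first value at this core that is a number and not a limit. Placing 2-methylphenyl in place of 4-methoxyphenyl at this position gives an at least 1.0-fold lower number from compound 1 to compound 4 (0.03 log units; that floor lies within the scatter). That floor is all that can be read, and the full size stays open because compound 1 rests on a limit: the limit of > 23000 nM in this assay, at which 1 of the 4 values shown sits.

The compounds shown leave open whether this change has any effect beyond the scatter. They also leave open whether an amine or a carboxylic acid at this position would move the number.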